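Methoxy in Place of Hydrogen: Expecting Little Change

The compounds below may be only part of what the source reports. "The series", "measured", "known", "first", "only" and "open" are said of these compounds alone.

Measured so far, in an assay on isolated protein for inhibition of Maltase-glucoamylase (Homo sapiens), with a stated time of 15 min; on this read-out higher numbers stand for weaker inhibition and lower numbers for stronger inhibition:
Compound 1 `O=C(N/N=C/c1ccccc1O)c1ccc(-c2nc3ccccc3s2)cc1` gives 5550 nM.
Compound 2 `O=C(N/N=C/c1ccc(O)c(O)c1)c1ccc(-c2nc3ccccc3s2)cc1` gives 15100 nM.
Compound 3 `O=C(N/N=C/c1ccccc1)c1ccc(-c2nc3ccccc3s2)cc1` gives 8050 nM.

Compound 3 has the second highest number of the three, and it sits within the usual scatter of both neighbours: the step of a 1.5-fold higher number from compound 1 to compound 3 (0.16 log units; within the scatter) and the step of a 1.9-fold lower number from compound 2 to compound 3 (0.27 log units; within the scatter) are both too small to read as real changes. On these numbers alone the three measured compounds cannot be put in order of inhibiting strength.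

Compound 4 `COc1ccc(/C=N/NC(=O)c2ccc(-c3nc4ccccc4s3)cc2)cc1` is the unmeasured compound. Its difference from compound 3 is methoxy in place of hydrogen on an aromatic carbon.

Going by the values given here, the steps that bear on this change are the ones that alter the same ring. Removing a hydroxy from that ring gives a 1.5-fold higher number from compound 1 to compound 3 (0.16 log units; within the scatter), within the scatter; replacing the whole ring gives a 1.9-fold lower number from compound 2 to compound 3 (0.27 log units; within the scatter), also within the scatter. Only a 2.7-fold higher number from compound 1 to compound 2 (0.43 log units; beyond the scatter) goes beyond it, and that step points towards weaker inhibition. Because the step of a 1.5-fold higher number from compound 1 to compound 3 (0.16 log units; within the scatter) stays within the scatter, a single methoxy added to compound 3 is expected to shift the number little, if at all, and a 1.1-fold higher number from compound 3 to compound 4 (0.05 log units; within the scatter) is the expected step. The estimate for compound 4 in this assay is 9000 nM, with a range of 4000 nM to 20000 nM.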

Compound 4, half-maximal inhibitory concentration: 18300 nM
Estimate against measurement, compound 4: 2.0-fold (0.31 log units) below; the measured number falls inside the stated range.
By their numbers in this assay, from the lowest: compounds 1, 3, 2 and 4 (each within the scatter of the next, the first and the last beyond it).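

In this assay, going by these compounds alone, the earlier compounds showed no step beyond the scatter for removing a single hydroxy from this ring, but methoxy in place of hydrogen, para to a large group, gives a 2.3-fold higher number from compound 3 to compound 4 (0.36 log units; beyond the scatter), a modest shift towards weaker inhibition. Set against the other two ring patterns, the 4-methoxyphenyl ring cannot be told apart from the 3,4-dihydroxyphenyl ring, with a 1.2-fold higher number from compound 2 to compound 4 (0.08 log units; within the scatter), whereas replacing the 2-hydroxyphenyl ring with it gives a 3.3-fold higher number from compound 1 to compound 4 (0.52 log units; beyond the scatter), again towards weaker inhibition. No available measurement gives a reason for these steps.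

The compounds shown leave open whether the shift belongs to methoxy itself or would also come with another group in the same place, such as an amine, a carboxylic acid or a longer chain like ethoxy. They also leave open whether methoxy on a different carbon of this ring would give a step of similar size and direction.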